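The compounds below may be only part of what the source reports. "The series", "measured", "known", "first", "only" and "open" are said of these compounds alone.

Measured so far in an ADME assay on Karpas-1106P cells (Homo sapiens) for cytotoxicity; a higher number here means that more compound is needed for the effect, a lower number that less compound is needed:
Compound 1 `Cc1ccc(S(=O)(=O)N[C@@H](CC(=O)NC(C)(C)C)C(=O)NCCNC(=O)c2cc(Cl)ccn2)cc1`: > 11100 nM, a limit
Compound 2 `Cc1ccc(S(=O)(=O)N[C@@H](CC(=O)NC(C)(C)C)C(=O)NCCNC(=O)c2cccc(C(C)C)c2)cc1`: > 11100 nM, a limit
Compound 3 `COc1cccc(C(=O)NCCNC(=O)[C@H](CC(=O)NC(C)(C)C)NS(=O)(=O)c2ccc(C)cc2)c1`: > 11100 nM, a limit

Compound 3 gives > 11100 nM in this assay, which is a limit of the assay and not a number. The other two compounds offer no firmer footing, as the whole set shows (the limit of > 11100 nM in this assay, at which 3 of the 3 values shown sit).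

Compound 4 `Cc1ccc(S(=O)(=O)N[C@@H](CC(=O)NC(C)(C)C)C(=O)NCCNC(=O)c2ccccc2F)cc1` keeps the shared core and changes one group: 2-fluorophenyl in place of 3-methoxyphenyl on a carbonyl carbon.

Among the compounds with values here, three measured steps concern this same group. Putting 3-isopropylphenyl in place of 4-chloropyridin-2-yl gives a step that the two limits leave unreadable from compound 1 to compound 2. Putting 3-methoxyphenyl in place of 4-chloropyridin-2-yl gives a step that the two limits leave unreadable from compound 1 to compound 3. Putting methoxy in place of isopropyl on an aromatic carbon gives a step that the two limits leave unreadable from compound 2 to compound 3. None of the three has a readable size, so they point to no particular size or direction for the new change.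

The simplest expectation is that compound 4 also ends at the limit, as did compound 3 with > 11100 nM. The estimated change is a step that the limit leaves unreadable from compound 3 to compound 4. For compound 4 the expected value is 14000 nM, with an estimated range from 6000 nM to 30000 nM.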

Compound 4, half-maximal effective concentration: > 11100 nM
Compound 4: a limit, no number (the forecaster's own chance of this, stated with the estimate: 85%); the middle value does not contradict the limit.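

In this assay compound 4 gives > 11100 nM, a limit of the assay and not a number. Its steps to compound 1, compound 2 and compound 3 cannot be read, since all four compounds end the same way: the limit of > 11100 nM in this assay, at which 4 of the 4 values shown sit.

The compounds shown leave open how much of each is needed for the effect, and whether changing this group alters that amount.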